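The compounds below may be only part of what the source reports. "The series", "measured", "known", "first", "only" and "open" are said of these compounds alone.

Measured so far in a functional assay on NCI-H23 cells (Homo sapiens) for cytotoxicity, read by sulforhodamine B assay, with a stated time of 24 h; on this read-out lower numbers stand for stronger inhibition of growth and higher numbers for weaker inhibition of growth:
compound 1 `COc1ccc(C(=O)/C=C/c2cc3ccccc3[nH]c2=O)cc1`: 14900 nM
compound 2 `O=C(/C=C/c1cc2ccccc2[nH]c1=O)c1ccc(O)cc1`: 20000 nM

Compound 2 gives the highest of the two numbers; the nearest is compound 1, and the step of a 1.3-fold higher number from compound 1 to compound 2 (0.13 log units; within the scatter) stays within the scatter. Compound 3 `O=C(/C=C/c1cc2ccccc2[nH]c1=O)c1ccc(Cl)cc1` has not been measured. It differs from compound 2 by chloro in place of hydroxy on an aromatic carbon — chloro in place of hydroxy on an aromatic carbon, para to a large group; cut one bond further out, 4-hydroxyphenyl to 4-chlorophenyl. Among the compounds with values here, the only measured step at this position is a 1.3-fold higher number from compound 1 to compound 2 (0.13 log units; within the scatter), a swap of the substituent on the oxygen; it bears on the site but not on the chloro itself, and no measured step contains a chloro group. Given that this one step is within the scatter, no step beyond the scatter is expected in this assay for compound 3; the expected step of a 1.3-fold lower number from compound 2 to compound 3 (0.12 log units; within the scatter) is small. Compound 3 is estimated at 15000 nM, in the range 6000 nM to 40000 nM.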

Compound 3, concentration for total growth inhibition: 93300 nM
For compound 3 the middle estimate is 6.2-fold (0.79 log units) below the measured one, and the stated range ends below it.
By their numbers in this assay, from the lowest: compounds 1 and 2 (each within the scatter of the next); then compound 3.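

In this assay this position proves sensitive to the group it carries, which the hydroxy and methoxy pair of compounds could not show. Chloro in place of hydroxy gives a 4.7-fold higher number from compound 2 to compound 3 (0.67 log units; beyond the scatter) and chloro in place of methoxy gives a 6.3-fold higher number from compound 1 to compound 3 (0.80 log units; beyond the scatter), so compound 3 is the weakest of the three, while compound 1 and compound 2 remain within the scatter of each other. No available evidence bears on the origin of this loss.

A single chloro compound does not show whether the oxygen-linked groups are favoured or chloro alone is disfavoured. From the compounds shown here alone, whether an amine, a carboxylic acid or a longer alkoxy chain at this place would read like hydroxy and methoxy or like chloro remains open.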